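Five-membered aryl in place of pyridin-3-yl on compound 3

The source may report more compounds than this note shows. Statements on the series, on what has been measured and on what is new or still open speak of the compounds shown alone.

Measured compounds:
compound 1 `c1ccc(-c2cccc3c2CCC3c2ncc[nH]2)nc1` — in a functional assay on CHO cells for agonist activity at Alpha-1A adrenergic receptor (Homo sapiens), read by FLIPR and calcium flux (on this read-out lower numbers stand for an effect already at smaller amounts and higher numbers for an effect only at larger amounts of compound), compound 1 gives 1150 nM
compound 2 `COc1cccc2c1CCC2c1ncc[nH]1` — compound 2 gives 32 nM
compound 3 `c1cncc(-c2cccc3c2CCC3c2ncc[nH]2)c1` — compound 3 gives 2060 nM

Compound 3 holds the highest of the three numbers. Its nearest neighbour is compound 1, with a 1.8-fold higher number from compound 1 to compound 3 (0.25 log units; within the scatter), a step within the scatter. The furthest is compound 2, with a 64-fold higher number from compound 2 to compound 3 (1.81 log units; beyond the scatter), a large step beyond the scatter; the companion step a 36-fold lower number from compound 1 to compound 2 (1.56 log units; beyond the scatter) is of the same kind.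

Compound 4 `Cn1cc(-c2cccc3c2CCC3c2ncc[nH]2)cn1` is not yet measured. It differs from compound 3 in one place: 1-methyl-1H-pyrazol-4-yl in place of pyridin-3-yl on an aromatic carbon.

Within the data shown here, the one measured step that bears directly on this change is the aryl-for-aryl swap a 1.8-fold higher number from compound 1 to compound 3 (0.25 log units; within the scatter), which stayed within the scatter. The two large steps both involve the methoxy compound 2 and do not concern an exchange of one aromatic ring for another, so they carry little weight here. Among the measured compounds shown here, only one aryl-to-aryl pair is available, so the expectation rests on a thin base. On that base no step beyond the scatter is expected in this assay; the estimated step is a 1.0-fold lower number from compound 3 to compound 4 (0.01 log units; within the scatter). For compound 4 the expected value is 2000 nM, with a range from 600 nM to 7000 nM.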

Compound 4, half-maximal effective concentration: > 2900 nM
Compound 4: only a limit was reported; the forecaster's own chance of this, stated with the estimate: 10%; at least 1.4-fold (0.16 log units) between middle value and limit.
By their numbers in this assay, from the lowest: compound 2; then compounds 1 and 3 (each within the scatter of the next). At a limit, above all of these: compound 4.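

In this assay, compound 4 is reported only as a limit: the limit of > 2900 nM in this assay, at which 1 of the 4 values shown sits. Among these compounds, the change from pyridin-3-yl to 1-methyl-1H-pyrazol-4-yl reads as an at least 1.4-fold higher number from compound 3 to compound 4 (0.14 log units; that floor lies within the scatter), so a five-membered aromatic ring with 2 hetero atoms in this place cannot be told apart from the six-membered ring it replaces, while the exchange of pyridin-2-yl for the same group reads as an at least 2.5-fold higher number from compound 1 to compound 4 (0.40 log units; beyond the scatter), the first step between two aromatic rings on this carbon whose floor lies beyond the scatter. The comparison with methoxy reads as an at least 90-fold higher number from compound 2 to compound 4 (1.95 log units; beyond the scatter), which makes three aromatic rings on this aromatic carbon, each with a step from methoxy that lies beyond the scatter, and extends that gap from six-membered rings to a five-membered one.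

The compounds shown leave open how small or non-aromatic groups behave in this place, such as ethoxy, a hydroxyl or an amine, and so whether the low number of compound 2 belongs to methoxy alone. Going by these compounds, how far the true number of compound 4 lies from its limit also remains open, and with it the full size of all three steps.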